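A few compounds are considered here, and "the series" means these few. Any claim that something is new, unique, unknown or untested is made for them only; others in the source may bear on it.

Measured compounds in a functional assay on the whole organism (strain Swiss) with Mus musculus as the target, in the maximal electroshock model, with a stated time of 0.25 h, at a dose of 300 mg/kg by the intraperitoneal route; a higher number here means a stronger effect of the compound at the dose given, a lower number a weaker effect:
compound 1 `CCC(C(=O)N1CCN(c2ccc(Cl)cc2)CC1)N1C(=O)CCC1=O` gives 0%.
compound 2 `CCC(C(=O)N1CCN(c2cccc(C)c2)CC1)N1C(=O)CCC1=O` gives 100%.
compound 3 `CCC(C(=O)N1CCN(c2cccc(F)c2)CC1)N1C(=O)CCC1=O` gives 75%.

Compound 3 stands second highest of the three numbers: compound 2 lies above it, as a number 25 percentage points lower from compound 2 to compound 3 (beyond the scatter) shows, and compound 1 lies far below it, as a number 75 percentage points higher from compound 1 to compound 3 (beyond the scatter) shows. Compound 4 `CCC(C(=O)N1CCN(c2ccccc2Cl)CC1)N1C(=O)CCC1=O` has not yet been measured in this assay. It differs from compound 3 in one place: 2-chlorophenyl in place of 3-fluorophenyl on an amine nitrogen in a ring.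

Within the data shown here, no measured step puts a chlorine on the 2-position of this phenyl ring, so the nearest guides are the step of a number 75 percentage points higher from compound 1 to compound 3 (beyond the scatter), where the only chlorine-bearing ring sat at the bottom of the series, and the step of a number 25 percentage points lower from compound 2 to compound 3 (beyond the scatter), which shows that changing the group on this ring can move the read-out by a modest amount. A downward step is therefore expected, of uncertain size, and a number 25 percentage points lower from compound 3 to compound 4 (beyond the scatter) is the estimate. For compound 4 the expected value in this assay is 50%, within a range from 0% to 100%.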

Compound 4, a percentage reported as activity, at one dose (the size of the read-out at that dose, not a potency): 50%
The estimate for compound 4 equals the measured number at the digits printed; the range from low to high includes it.
By their numbers in this assay, from the lowest: compound 1; then compound 4; then compound 3; then compound 2.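

In this assay, 2-chlorophenyl in place of 4-chlorophenyl gives a number 50 percentage points higher from compound 1 to compound 4 (beyond the scatter), so a chlorine on this phenyl ring does not by itself abolish the read-out, and where the chlorine stands on the ring matters. The same group still falls short of both other rings, with a number 25 percentage points lower from compound 3 to compound 4 (beyond the scatter) and a number 50 percentage points lower from compound 2 to compound 4 (beyond the scatter), so in these four compounds 3-methylphenyl and 3-fluorophenyl keep the higher read-outs. No measured property is available to account for these steps.

The compounds shown leave open how 3-chlorophenyl would read, which would compare chlorine with methyl and fluoro in the same named position. Also open, from the compounds shown here alone, is whether a methoxy or trifluoromethyl group on this phenyl ring would keep the read-out of the shared core.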